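The compounds below may be only part of what the source reports. "The series", "measured", "known", "first", "only" and "open" are said of these compounds alone.

Of the compounds shown here, three have so far been tested in an ADME assay on RD cells (Homo sapiens) for cytotoxicity, read by MTT assay, with a stated time of 3 days; a lower number here means that less compound is tolerated, a higher number that more compound is tolerated. Compound 1 `CCC[C@H](CCn1cncn1)c1ccccc1` gives 63.1 ug/mL there, compound 2 `CCCC[C@H](CCn1cncn1)c1ccccc1` gives 48.3 ug/mL and compound 3 `CCCC[C@@H](CCn1cncn1)c1ccccc1` gives 47.5 ug/mL. On the numbers shown compound 2 stands second highest of three, though all three lie within the scatter of one another: the step of a 1.3-fold lower number from compound 1 to compound 2 (0.12 log units; within the scatter) is small, and so is the step of a 1.0-fold lower number from compound 2 to compound 3 (0.01 log units; within the scatter) because of the fact that compounds 2 and 3 differ only in the configuration as drawn. Compound 4 `CCCC[C@H](CCn1cncn1)c1ccc(F)cc1` differs from compound 2 by fluoro in place of hydrogen on an aromatic carbon. Neither measured step touches the aromatic ring, so none bears directly on this change; both were within the scatter. For compound 4 the expected step is a 1.0-fold lower number from compound 2 to compound 4 (0.00 log units; within the scatter), nothing beyond the scatter. Compound 4 is therefore estimated at 48 ug/mL, with a range of 30 ug/mL to 75 ug/mL.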

Compound 4, half-maximal cytotoxic concentration: 35.2 ug/mL
Beside the measured number, compound 4's estimate is 1.4-fold (0.13 log units) above it, within the range that was stated.
By their numbers in this assay, from the lowest: compounds 4, 3, 2 and 1 (each within the scatter of the next).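

In this assay, fluoro in place of hydrogen on an aromatic carbon, para to a large group, is the only change to the aromatic ring among the compounds shown, and it gives a 1.4-fold lower number from compound 2 to compound 4 (0.14 log units; within the scatter). For this one pair, the aromatic ring therefore accepts fluoro at this position with the number staying within the scatter. Nothing available bears on a cause for this step. On these data alone, whether a chloro group or an amine at this same position would give a step beyond the scatter remains open. So does the effect of a longer chain with fluoro kept in place.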